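The compounds below may be only part of what the source reports. "The series", "measured", "known", "first", "only" and "open" are said of these compounds alone.

Measured so far:
compound 1 `O=C(Nc1cccc(-c2oc3cc(-c4ccc(F)cc4)ccc3c(=O)c2O)c1)c1ccc(C(F)(F)F)cc1` — 19400 nM
compound 2 `Cc1cccc(C(=O)Nc2cccc(-c3oc4cc(-c5ccc(F)cc5)ccc4c(=O)c3O)c2)c1` — 16500 nM

In a functional assay on A549 cells (Homo sapiens) for antiproliferative activity, read by CCK-8 assay, with a stated time of 72 h (on this read-out lower numbers stand for stronger inhibition and higher numbers for weaker inhibition), compound 1 gives 19400 nM and compound 2 gives 16500 nM; these two numbers sit within the usual scatter of each other, so neither compound can be placed ahead of the other. Within the data shown here, the only measured step, a 1.2-fold lower number from compound 1 to compound 2 (0.07 log units; within the scatter), swaps one whole aryl group on the carbonyl carbon for another. Compound 3 `Cc1cc(C(=O)Nc2cccc(-c3oc4cc(-c5ccc(F)cc5)ccc4c(=O)c3O)c2)ccc1F` differs from compound 2 by fluoro in place of hydrogen on an aromatic carbon. Among the measured compounds shown here, no measured step touches a change of this kind, so the expectation rests on compound 2 alone: a step of a 1.1-fold lower number from compound 2 to compound 3 (0.04 log units; within the scatter) in this assay is expected, meaning no shift beyond the scatter. Compound 3 is therefore estimated at 15000 nM, with a range from 6000 nM to 38000 nM.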

Compound 3, half-maximal inhibitory concentration: 11500 nM
Compound 3: middle estimate off by 1.3-fold (0.12 log units), on the high side, and the stated range covers the measured number.
By their numbers in this assay, from the lowest: compounds 3, 2 and 1 (each within the scatter of the next).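

In this assay, fluoro on this aromatic carbon, ortho to the methyl group and para to a large group, gives a 1.4-fold lower number from compound 2 to compound 3 (0.16 log units; within the scatter) and so adds a change at a new position without a shift beyond the scatter. Exchanging the whole 4-(trifluoromethyl)phenyl for 4-fluoro-3-methylphenyl gives a 1.7-fold lower number from compound 1 to compound 3 (0.23 log units; within the scatter) and also stays within the scatter, which leaves all three compounds level in this assay. No available measurement offers an explanation for these numbers. Still open, as far as these compounds go, is whether chloro in place of fluoro, or an amine or a carboxylic acid on this ring, would move the number beyond the scatter.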